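Adding a Chloro Group to the Core of Compound 3

A few compounds are considered here, and "the series" means these few. Any claim that something is new, unique, unknown or untested is made for them only; others in the source may bear on it.

Compound 3 `CCCCCCCCCCCNC(=O)Oc1ccc(Cl)cc1C(=O)Nc1ccc(Cl)cc1` gives 64 h in an ADME assay for metabolic stability, read by HPLC, at pH 7; on this read-out higher numbers stand for a longer-lived compound and lower numbers for a shorter-lived compound. Compound 1 `CCCCCNC(=O)Oc1ccc(Cl)cc1C(=O)Nc1ccc(Cl)cc1` gives 64 h and compound 2 `CCCCCCCCCNC(=O)Oc1ccc(Cl)cc1C(=O)Nc1ccc(Cl)cc1` gives 64 h in this assay, so compound 3 stands level with both. The steps of no change at the digits printed from compound 1 to compound 2 (within the scatter), no change at the digits printed from compound 1 to compound 3 (within the scatter) and no change at the digits printed from compound 2 to compound 3 (within the scatter) all stayed within the scatter, and every one of them concerned the saturated chain. Compound 4 `CCCCCCCCCCCNC(=O)Oc1ccc(Cl)cc1C(=O)Nc1ccc(Cl)c(Cl)c1` differs from compound 3 by chloro in place of hydrogen on an aromatic carbon. Within the data shown here, no measured step touches an aromatic carbon, so nothing here speaks directly to this change; the only guide is that every change tried so far left this assay unmoved. Compound 4 is therefore expected to stay within the scatter, no change at the digits printed from compound 3 to compound 4 (within the scatter). Compound 4 is estimated at 64 h, with a range from 32 h to 128 h.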

Compound 4, half-life: 64 h
Beside the measured number, compound 4's estimate shows no gap at the digits printed; the measured number falls inside the stated range.
By their numbers in this assay, from the lowest: compounds 1, 2, 3 and 4 (each within the scatter of the next).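

In this assay the change from 4-chlorophenyl to 3,4-dichlorophenyl gave no change at the digits printed from compound 3 to compound 4 (within the scatter) on an aromatic carbon ortho to a chloro group and meta to a large group. This is the first step shown away from the saturated chain, and it shows that this read-out also holds level for a chloro group entering at this aromatic position. Nothing measured here offers a reason for this. As far as these compounds go, whether an amine or a carboxylic acid in place of this hydrogen would also leave the half-life level stays open, as does the outcome of this chloro group alongside a pentyl chain.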